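Shortening the acid chain of a naphthylsulfonyl pyrrolidine

The source may hold more compounds than are shown below. What is called first, only, known or untested is meant among the compounds shown, and "the series" means these compounds.

Among the measured compounds shown here, in a functional assay on the whole organism (trachea) for inhibition, with Cavia porcellus as the target (on this read-out higher numbers stand for an effect only at larger amounts of compound and lower numbers for an effect already at smaller amounts), compound 2 `O=C(O)CCC/C=C\C[C@@H]1CN(S(=O)(=O)c2cccc3ccccc23)C[C@@H]1c1ccccc1O` gives 0.08 mg/kg, the lowest of the two numbers so far, whereas compound 1 `O=C(O)CC/C=C\C[C@@H]1CN(Cc2cccnc2)C[C@@H]1c1ccccc1O` gives 1 mg/kg, a gap beyond the scatter. Compound 3 `O=C(O)CC/C=C\C[C@@H]1CN(S(=O)(=O)c2cccc3ccccc23)C[C@@H]1c1ccccc1O` differs from compound 2 by a single change: carboxy in place of carboxymethyl on a saturated chain carbon, two bonds along the chain from a double-bonded chain carbon. For the measured compounds named here, no measured pair isolates this change, so its size can only be guessed. In this assay a modest weakening is expected, estimated at a 2.5-fold higher number from compound 2 to compound 3 (0.40 log units; beyond the scatter). Compound 3 is therefore expected to give about 0.2 mg/kg in this assay, within a range from 0.05 mg/kg to 0.8 mg/kg.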

Compound 3, dose for 50% inhibition: 0.0075 mg/kg
Beside the measured number, compound 3's estimate is 27-fold (1.43 log units) above it, outside the stated range (below it).
By their numbers in this assay, from the lowest: compound 3; then compound 2; then compound 1.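

Taking carboxy in place of carboxymethyl at this position gives an 11-fold lower number from compound 2 to compound 3 (1.03 log units; beyond the scatter) in this assay, so the shorter acid chain acts at far smaller amounts and the length of this chain matters strongly. Compound 1 and compound 2 could not show this, as they differ in more than one place. No measured evidence bears on why this step is so large.

The compounds shown leave open whether a still shorter chain, or an amide or a tetrazole in place of the carboxylic acid, would keep an effect at such small amounts.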